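A few compounds are considered here, and "the series" means these few. Any claim that something is new, unique, unknown or untested is made for them only; others in the source may bear on it.

Compound 1 `Cc1nc(-c2ccccc2)c(C(=O)N2CCN(c3c(C)cccc3C)CC2)o1` gives 146 nM in a functional assay on HL-60 cells (Homo sapiens) for inhibition, read by MTT assay, with a stated time of 72 h; a lower number here means a stronger inhibitor, a higher number a weaker inhibitor. Compound 2 `Cc1nc(-c2ccccc2)c(C(=O)N2CCN(c3cccc(C#N)c3)CC2)o1` gives 39.6 nM. Compound 3 `Cc1nc(-c2ccccc2)c(C(=O)N2CCN(c3ccc(C(F)(F)F)cc3)CC2)o1` gives > 1000 nM, which is a limit of the assay rather than a number (the limit of > 1000 nM in this assay, at which 1 of the 3 values shown sits).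

Compound 3 thus sits at the weak end of the three: the steps of an at least 6.8-fold higher number from compound 1 to compound 3 (0.83 log units; beyond the scatter) and an at least 25-fold higher number from compound 2 to compound 3 (1.40 log units; beyond the scatter) are both beyond the scatter. Compound 4 `Cc1nc(-c2ccccc2)c(C(=O)N2CCN(c3ccc(C)c(C)c3)CC2)o1` differs from compound 3 by 3,4-dimethylphenyl in place of 4-(trifluoromethyl)phenyl on an amine nitrogen in a ring. Both measured steps into compound 3 bring in 4-(trifluoromethyl)phenyl and raise the number; compound 4 instead carries a dimethylphenyl, as compound 1 does. A lower number is therefore expected for compound 4, an at least 5.0-fold lower number from compound 3 to compound 4 (0.69 log units; beyond the scatter), though from a limit its size is uncertain. Compound 4 is estimated at 200 nM, with a range of 50 nM to 1500 nM.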

Compound 4, half-maximal inhibitory concentration: 43 nM
Beside the measured number, compound 4's estimate is 4.7-fold (0.67 log units) above it; the measured number lies below the stated range.
By their numbers in this assay, from the lowest: compounds 2 and 4 (each within the scatter of the next); then compound 1. At a limit, above all of these: compound 3.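

At this place on the amine nitrogen in a ring, a dimethylphenyl does not fix the number in this assay: moving to 3,4-dimethylphenyl gives a 3.4-fold lower number from compound 1 to compound 4 (0.53 log units; beyond the scatter). The step of an at least 23-fold lower number from compound 3 to compound 4 (1.36 log units; beyond the scatter) starts from a limit and leaves the loss with 4-(trifluoromethyl)phenyl alone among the aryl groups shown. A nitrile is not needed for the lowest numbers in this set, as a 1.1-fold higher number from compound 2 to compound 4 (0.04 log units; within the scatter) shows.

Open, on these data alone, is whether a methoxy group, a chlorine or a single methyl on the phenyl keeps these numbers. Also open, as far as these compounds go, is how a pyridine in place of the phenyl would read.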